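The source may report more compounds than this note shows. Statements on the series, on what has been measured and on what is new or still open speak of the compounds shown alone.

Measured so far in an assay on isolated protein for inhibition of Rho-associated protein kinase 1 (Homo sapiens), read by scintillation counting, radiometric assay and 33P incorporation, with a stated time of 40 min, in the presence of a further agent that is not named here; on this read-out lower numbers stand for stronger inhibition and higher numbers for weaker inhibition:
compound 1 `Cc1ccc(C(=O)Nc2cccc(NC(=O)COc3ccc4c(=O)ccoc4c3)c2)cc1` gives 183 nM
compound 2 `CCCc1ccc(C(=O)Nc2cccc(NC(=O)COc3ccc4c(=O)ccoc4c3)c2)cc1` gives 143 nM
compound 3 `COc1ccc(C(=O)Nc2cccc(NC(=O)COc3ccc4c(=O)ccoc4c3)c2)cc1` gives 18 nM

Compound 3 carries the lowest number of the three. The steps of a 10-fold lower number from compound 1 to compound 3 (1.01 log units; beyond the scatter) and a 7.9-fold lower number from compound 2 to compound 3 (0.90 log units; beyond the scatter) both lie beyond the scatter, whereas a 1.3-fold lower number from compound 1 to compound 2 (0.11 log units; within the scatter) lies within it, so compound 1 and compound 2 are not separated from each other.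

Compound 4 `O=C(COc1ccc2c(=O)ccoc2c1)Nc1cccc(NC(=O)c2ccc(OC(F)(F)F)cc2)c1` differs from compound 3 by trifluoromethyl in place of methyl on an oxygen on an aromatic ring. Among the measured compounds shown here, no measured pair carries this exact change. For the measured compounds named here, the steps that bear on it do so only indirectly: the two steps into compound 3, a 10-fold lower number from compound 1 to compound 3 (1.01 log units; beyond the scatter) and a 7.9-fold lower number from compound 2 to compound 3 (0.90 log units; beyond the scatter), show that the group on that aromatic carbon moves the read-out by a large amount, and that the methoxy compound stands apart from the methyl and propyl compounds. Going by the values given here, compound 4 keeps the oxygen of compound 3 but not its methyl, and no measured compound tells how much of the gain of compound 3 rests on each part. Relative to compound 3, a modest rise in the number is expected for compound 4, a 2.8-fold higher number from compound 3 to compound 4 (0.44 log units; beyond the scatter), with a wide range on either side. Compound 4 is estimated at 50 nM in this assay, with a range from 15 nM to 200 nM.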

Compound 4, half-maximal inhibitory concentration: 869 nM
Estimate against measurement, compound 4: 17-fold (1.24 log units) below, outside the stated range (above it).
By their numbers in this assay, from the lowest: compound 3; then compounds 2 and 1 (each within the scatter of the next); then compound 4.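

In this assay, the oxygen on the aromatic carbon is not enough to hold the low number of compound 3: replacing only the methyl on that oxygen with trifluoromethyl gives a 48-fold higher number from compound 3 to compound 4 (1.68 log units; beyond the scatter), the largest new step at this position. The trifluoromethoxy compound also does not return to the level of the methyl and propyl compounds, since the series shows a 4.7-fold higher number from compound 1 to compound 4 (0.68 log units; beyond the scatter) and a 6.1-fold higher number from compound 2 to compound 4 (0.78 log units; beyond the scatter), each beyond the scatter. The group at this place can therefore move the number in either direction from methyl: down with methoxy and up with trifluoromethoxy, making compound 4 the highest of the four. Nothing measured here accounts for this split between two groups that both keep the oxygen.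

Going by these compounds, it remains open whether the low number of compound 3 depends on methoxy itself or extends to ethoxy, hydroxyl or difluoromethoxy on the same aromatic carbon. A dimethylamino group or a plain trifluoromethyl group there would also show how much of the rise in compound 4 goes with the oxygen.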